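Swapping Ethynyl for Methyl on a Fatty Acid Receptor Agonist

The source may hold more compounds than are shown below. What is called first, only, known or untested is meant among the compounds shown, and "the series" means these compounds.

In an in vitro functional assay on 1321-N1 cells for agonist activity at Free fatty acid receptor 1 (Homo sapiens), read by fluorescence (on this read-out lower numbers stand for an effect already at smaller amounts and higher numbers for an effect only at larger amounts of compound), compound 1 `C#Cc1cccc(C#Cc2ccc(CCC(=O)O)cc2)c1` gives 155 nM, the second highest of the three numbers measured. Compound 2 `O=C(O)CCc1ccc(C#Cc2cccc([N+](=O)[O-])c2)cc1` gives 58.9 nM, and compound 3 `Cc1cccc(C#Cc2ccc(OCC(=O)O)cc2)c1` gives 513 nM. Among the measured compounds shown here, the only measured step on the shared core, a 2.6-fold lower number from compound 1 to compound 2 (0.42 log units; beyond the scatter), shows a modest gain from one exchange at that aromatic carbon. Compound 4 `Cc1cccc(C#Cc2ccc(CCC(=O)O)cc2)c1` differs from compound 1 by methyl in place of ethynyl on an aromatic carbon. For the measured compounds named here, no measured step exchanges ethynyl for methyl directly, and compound 3 carries a methyl but on a different acid chain, so the guide is weak. A number close to that of compound 1 is expected, and compound 4 is estimated at 200 nM, between 80 nM and 500 nM, which would mean a 1.3-fold higher number from compound 1 to compound 4 (0.11 log units; within the scatter).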

Compound 4, half-maximal effective concentration: 43.7 nM
For compound 4 the middle estimate is 4.6-fold (0.66 log units) above the measured one; the whole stated range lies above it.
By their numbers in this assay, from the lowest: compounds 4 and 2 (each within the scatter of the next); then compound 1; then compound 3.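

Ethynyl is not needed at this aromatic carbon: methyl in its place gives a 3.5-fold lower number from compound 1 to compound 4 (0.55 log units; beyond the scatter), and methyl and nitro cannot be told apart there, with a 1.3-fold lower number from compound 2 to compound 4 (0.13 log units; within the scatter). The acid chain counts as well, as 2-carboxyethyl in place of carboxymethoxy gives a 12-fold lower number from compound 3 to compound 4 (1.07 log units; beyond the scatter), the only large step among those shown. Whether a group as small as methyl is enough at this position therefore now has a first answer on the 2-carboxyethyl chain. Going by these compounds, whether an ethyl or an amine at this aromatic carbon would keep the number this low remains open. Nothing measured here gives a reason for these steps.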